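The compounds below may be only part of what the source reports. "The series", "measured", "known", "first", "only" and "open" are said of these compounds alone.

Four compounds built on one shared core are compared in a functional assay on PC-3 cells (Homo sapiens) for cytotoxicity, read by CCK-8 assay, with a stated time of 72 h; on this read-out lower numbers stand for stronger inhibition and higher numbers for weaker inhibition. Compound 1 `O=C(O)CC1CNC(=O)c2cc(Br)c(Br)n21` carries a free carboxylic acid on its side chain. In this assay compound 1 reaches only a limit, > 200000 nM. Compound 2 `CCOC(=O)CC1CNC(=O)c2cc(Br)c(Br)n21` differs from compound 1 by ethyl in place of hydrogen on an oxygen next to a carbonyl group. In this assay compound 2 gives 39000 nM. Capping the acid as its ethyl ester thus made an at least 5.1-fold lower number from compound 1 to compound 2 (0.70 log units; beyond the scatter).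

Compound 3 `O=C(O)CC1CNC(=O)c2ccc(Br)n21` keeps the free acid but has a different core; the two cores differ by hydrogen in place of bromo on an aromatic carbon. In this assay compound 3 also reaches only a limit, > 200000 nM. From the compounds shown here alone, the step that the two limits leave unreadable from compound 1 to compound 3 cannot be sized because of the limit of > 200000 nM in this assay, at which 2 of the 3 values shown sit, so whether the second bromine matters is unknown.

Compound 4 `CCOC(=O)CC1CNC(=O)c2ccc(Br)n21` has not yet been measured. It differs from compound 3 by ethyl in place of hydrogen on an oxygen next to a carbonyl group. This is the same change as the one between the first two compounds, and the surroundings of the altered oxygen are described in identical words for both pairs, so it is the same change on a different core. The expected step of an at least 2.8-fold lower number from compound 3 to compound 4 (0.45 log units; beyond the scatter) rests on the measured step of an at least 5.1-fold lower number from compound 1 to compound 2 (0.70 log units; beyond the scatter), though only its lower bound is known. Compound 4 is therefore estimated at about 70000 nM in this assay, with a likely range from 25000 nM to 200000 nM, and some chance that it again reaches only a limit.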

Compound 4, half-maximal inhibitory concentration: 29000 nM
Beside the measured number, compound 4's estimate is 2.4-fold (0.38 log units) above it; measured number inside the range.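

Turning the free acid into its ethyl ester gives an at least 6.8-fold lower number from compound 3 to compound 4 (0.83 log units; beyond the scatter) in this assay, so the change that helped on the core of compound 1 points the same way on the core of compound 3, and the two steps can be set side by side: the same change on two cores in this assay, an at least 5.1-fold lower number (0.70 log units; beyond the scatter) from compound 1 to compound 2 and an at least 6.8-fold lower number (0.83 log units; beyond the scatter) from compound 3 to compound 4; the limit leaves it open whether they differ

What this does not show is how large either step truly is, or whether the change is worth more on one core than on the other. Both acids, compound 1 and compound 3, are limits rather than numbers, so each step is only a lower bound, and the step between those two acids cannot be read: the limit of > 200000 nM in this assay, at which 2 of the 4 values shown sit.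

Between the two esters, hydrogen in place of bromo on an aromatic carbon gives a 1.3-fold lower number from compound 2 to compound 4 (0.13 log units; within the scatter), so with the ester in place the second bromine makes no difference that stands out from the scatter.

These compounds leave open whether a methyl ester, a longer chain on the oxygen or an amide in place of the ester would behave like the ethyl ester. They also leave open whether the change would carry over to a core with chloro in place of the remaining bromo.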